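This account rests on a few compounds, and the source may have more. Where it says the series, first, only, none or still open, it means among the compounds named here.

Measured compounds:
compound 1 `COC(=O)CC(=O)N1N=C(c2ccc(-n3cncn3)cc2)CC1c1ccc(N(C)C)cc1`: 1.5%
compound 2 `COC(=O)CC(=O)N1N=C(c2ccc(-n3ccnc3)cc2)CC1c1ccc(N(C)C)cc1`: -0.1%

Both were tested in a functional assay on NCI-H1975 cells (Homo sapiens) for inhibition, read by sulforhodamine B assay, tested at 10 uM; on this read-out higher numbers stand for more inhibition at the one concentration tested (going by the name of the read-out) and lower numbers for less inhibition. Compound 1 gives 1.5% and compound 2 gives -0.1%; the step of a number 1.6 percentage points lower from compound 1 to compound 2 (within the scatter) is within the scatter, so compound 2 stands alongside compound 1, with essentially no inhibition at the single concentration tested.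

Compound 3 `CN(C)c1ccc(C2CC(c3ccc(-n4ccnc4)cc3)=NN2S(=O)(=O)c2ccc(C#N)cc2)cc1` has not yet been measured. It differs from compound 2 by (4-cyanophenyl)sulfonyl in place of ((methoxycarbonyl)methyl)carbonyl on an amine nitrogen in a ring. Among the measured compounds shown here, no measured step touches this ring nitrogen; the only step known, from compound 1 to compound 2, altered a group on an aromatic carbon and was within the scatter. Nothing in the data therefore points to a step in this assay beyond the scatter in either direction, and the expected change is a number 5.1 percentage points higher from compound 2 to compound 3 (within the scatter). Compound 3 is accordingly estimated at 5%, within a range from -10% to 30%; the range is wide, the change itself being untested.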

Compound 3, a percentage reported as inhibition, at one concentration (the size of the read-out at that concentration, not a potency): 0.7%
The estimate for compound 3 lay 4.3 percentage points above the measured number; low and high end bracket the measured number.
By their numbers in this assay, from the lowest: compounds 2, 3 and 1 (each within the scatter of the next).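

On the amine nitrogen in a ring, (4-cyanophenyl)sulfonyl in place of ((methoxycarbonyl)methyl)carbonyl gives in this assay a number 0.8 percentage points higher from compound 2 to compound 3 (within the scatter). Among the compounds shown here, this is the first look at this position, and the change is a substantial one: a chain with no ring leaves, and a group carrying a six-membered aromatic ring and a nitrile enters, yet the read-out still shows essentially no inhibition at the one concentration tested. No other measurement here bears on this result.

With all the numbers close to zero, the compounds shown cannot tell whether this position can affect the read-out at all. From the compounds shown here alone, whether a carboxylic acid or a short chain ending in an amine on this ring nitrogen would give a number beyond the scatter remains open.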